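The source may report more compounds than this note shows. Statements on the series, on what has been measured and on what is new or still open speak of the compounds shown alone.

Of the compounds shown here, three of one series have been measured in a functional assay on HeLa cells (Homo sapiens) for inhibition, read by CCK-8 assay, with a stated time of 72 h, tested at 2 uM (on this read-out higher numbers stand for more inhibition of growth at the one concentration tested and lower numbers for less inhibition of growth), and a fourth awaits its result. Compound 2 `Nc1ccccc1NC(=O)/C=C/c1ccc(CSc2ccc(Cl)cc2)cc1` gives 1.94% in this assay, and compound 1 `Cc1cc(C)cc(SCc2ccc(/C=C/C(=O)Nc3ccccc3N)cc2)c1` gives 11.7% in this assay. The change from compound 2 to compound 1 is 3,5-dimethylphenyl in place of 4-chlorophenyl on a sulfur, and it made a step of a number 9.8 percentage points higher from compound 2 to compound 1 (within the scatter). Compound 3 `Nc1ccccc1NC(=O)c1ccc(CSc2ccc(Cl)cc2)cc1` gives 19.2% in this assay, the highest of the three numbers; its gap to compound 1 lies within the scatter, while its gap to compound 2 lies beyond it. How the core of compound 3 differs from the core of compound 2 is not broken down here. Compound 4 `Cc1cc(C)cc(SCc2ccc(C(=O)Nc3ccccc3N)cc2)c1` carries the same change relative to compound 3, namely (3,5-dimethylphenyl in place of 4-chlorophenyl on a sulfur), on the same kind of place, and it is still to be tested in this assay. Since the earlier step between compound 2 and compound 1, a number 9.8 percentage points higher from compound 2 to compound 1 (within the scatter), stayed within the scatter, a step of about a number 5.8 percentage points higher from compound 3 to compound 4 (within the scatter) is expected for compound 4. Compound 4 is therefore estimated at 25% in this assay, with a plausible range from 8% to 42%.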

Compound 4, percent growth inhibition at one concentration: 40.2%
Compound 4: the middle estimate sits 15.2 percentage points below what was measured; measured number inside the range.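

In this assay, putting 3,5-dimethylphenyl in place of 4-chlorophenyl on the sulfur gave a number 21 percentage points higher from compound 3 to compound 4 (beyond the scatter). Set beside the same change on the other core, the size of this step cannot be told apart from the earlier one: the same change on two cores in this assay, a number 9.8 percentage points higher (within the scatter) from compound 2 to compound 1 and a number 21 percentage points higher (beyond the scatter) from compound 3 to compound 4, 11.2 percentage points apart, within the scatter of two such steps The number rose on both cores, which fits the change carrying over from one core to the other, but only the step on the core of compound 3 clears the scatter, and two cores read at one concentration show neither that the step has a fixed size nor why it arises.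

The compounds shown leave open how a plain phenyl, a 3-methylphenyl or a cyclohexyl on the same sulfur would read in this assay, and so whether both methyl groups are needed for the higher number. They also leave open whether the change would carry over to a core with a longer chain in place of the ones shown here.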